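The source may hold more compounds than are shown below. What is called first, only, known or untested is meant among the compounds shown, and "the series" means these compounds.

Of the compounds shown here, two from this series have been tested so far in a functional assay on FaDu cells (Homo sapiens) for cytotoxicity, read by MTT assay, with a stated time of 72 h; a higher number here means that more compound is tolerated, a lower number that less compound is tolerated. Compound 1 `COc1nc(NC(=O)C(=O)c2cn(C(C)C)c3ccccc23)ns1` gives only a limit in this assay, > 10000 nM, which is not a number but the edge of what the assay could report. Compound 2 `COC(=O)CCn1cc(C(=O)C(=O)Nc2ccc(OC)nc2)c2ccccc21` gives 168 nM in this assay. Since compound 1 and compound 2 differ in more than one place, their two values can only be set side by side; no single change accounts for the gap between them. The one firm point is that compound 1 sits at the limit of > 10000 nM in this assay, at which 1 of the 2 values shown sits.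

Compound 3 `COc1ncc(NC(=O)C(=O)c2cn(C(C)C)c3ccccc23)cn1` has not yet been measured in this assay. It differs from compound 1 in one place: a group of 8 heavy atoms (5 carbon, 2 nitrogen, 1 oxygen; one six-membered aromatic ring with 2 hetero atoms) in place of a group of 7 heavy atoms (3 carbon, 2 nitrogen, 1 oxygen, 1 sulfur; one five-membered aromatic ring with 3 hetero atoms), on an amide-type nitrogen. Within the data shown here, no step of this kind has been measured here, so the direction rests on the neighbourhood alone: compound 2, which also carries a six-membered aromatic ring on the amide-type nitrogen, shows 168 nM, which suggests some gain. The step from compound 1 to compound 3 is therefore expected to be an at least 5.0-fold lower number from compound 1 to compound 3 (0.69 log units; beyond the scatter) toward less compound being tolerated. For compound 3 the estimated value in this assay is 2000 nM, with a range from 300 nM to 10000 nM.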

Compound 3, concentration lethal to 50% of the cells: 171 nM
Compound 3: the middle estimate sits 12-fold (1.07 log units) above what was measured; measured number below the stated range.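

Among these compounds, on the amide-type nitrogen, putting 2-methoxypyrimidin-5-yl in place of the five-membered aromatic ring with 3 hetero atoms gives an at least 58-fold lower number from compound 1 to compound 3 (1.76 log units; beyond the scatter) in this assay, with the rest of the molecule unchanged, and this is the first comparison here in which a single change can be read. It shows that the group on this nitrogen can by itself decide whether the cells tolerate far less compound, at least for this pair on this shared core. The printed size is only a floor, and the real step may be larger, because one end of it is a limit of the assay and not a number: the limit of > 10000 nM in this assay, at which 1 of the 3 values shown sits.

The swap changes ring size, the number of hetero atoms and the presence of sulfur all at once, so the compounds shown cannot separate the share of each in the step. From the compounds shown here alone, it also remains open whether the methoxy group on the pyrimidine matters, which a plain phenyl ring on the same nitrogen, or an amine in place of the methoxy group, would help to settle.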